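Methoxycarbonyl Replaces Isopropyl on a Chain Near the Core

This account rests on a few compounds, and the source may have more. Where it says the series, first, only, none or still open, it means among the compounds named here.

Three compounds share one core and differ only in the chain on the saturated chain carbon bound to an aromatic nitrogen: compound 1 `CN(C)C(=O)Cn1nnc(CNC(=O)c2ccc(-c3ccccc3)cc2)n1`, compound 2 `CC(=O)Cn1nnc(CNC(=O)c2ccc(-c3ccccc3)cc2)n1` and compound 3 `CC(C)Cn1nnc(CNC(=O)c2ccc(-c3ccccc3)cc2)n1`. In an assay on isolated protein (COS cells) for inhibition of diacylglycerol lipase-alpha (Homo sapiens) (on this read-out higher numbers stand for weaker inhibition and lower numbers for stronger inhibition), compound 1 gives no number, only a limit, > 10000 nM. Compound 2 likewise gives only a limit, > 10000 nM. Compound 3 also stands at a limit, > 10000 nM. The steps a step that the two limits leave unreadable from compound 1 to compound 2, a step that the two limits leave unreadable from compound 1 to compound 3 and a step that the two limits leave unreadable from compound 2 to compound 3 cannot be sized because of the limit of > 10000 nM in this assay, at which 3 of the 3 values shown sit. Compound 4 `COC(=O)Cn1nnc(CNC(=O)c2ccc(-c3ccccc3)cc2)n1` differs from compound 3 by methoxycarbonyl in place of isopropyl on a saturated chain carbon bound to an aromatic nitrogen. With no readable step to lean on, the step that the limit leaves unreadable from compound 3 to compound 4 is expected to show no direction beyond the scatter. Compound 4 is therefore expected near 15000 nM, between 5000 nM and 50000 nM.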

Compound 4, half-maximal inhibitory concentration: > 10000 nM
Compound 4 ended at the assay's limit; the forecaster's own chance of this, stated with the estimate: 80%; the middle value is on the limit's open side.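

Within the data shown here, no step from compound 1, compound 2 or compound 3 to compound 4 can be read, because all four compounds sit at the same limit: the limit of > 10000 nM in this assay, at which 4 of the 4 values shown sit. The compounds shown leave open whether any group at this place gives inhibition that can be read as a number.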